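A few compounds are considered here, and "the series" means these few. Any claim that something is new, unique, unknown or untested is made for them only; others in the source may bear on it.

Compound 1 `Nc1cccc(Nc2c(C(=O)NCc3ccc(F)cc3)nc(Br)c3cccnc23)c1`: 8000 nM
Compound 2 `O=C(NCc1ccc(F)cc1)c1nc(Br)c2cccnc2c1NCCO`: "not determined" (no result reported)

Both compounds were taken into a functional assay on MCF7 cells (Homo sapiens) for cytotoxicity, read by MTT assay, with a stated time of 72 h (a higher number here means a weaker inhibitor, a lower number a stronger inhibitor), but only compound 1 gave a number. Going by these compounds, compound 2 stands without one, its entry reading "not determined" (no result reported), so its place on the scale is unknown. Compound 3 `CNCCCNc1c(C(=O)NCc2ccc(F)cc2)nc(Br)c2cccnc12` has yet to be measured. The change is (methylamino)methyl in place of hydroxy on a saturated chain carbon, two bonds along the chain from a nitrogen on an aromatic ring, with (methylamino)methyl in place of hydroxy on a saturated chain carbon, two bonds along the chain from a nitrogen on an aromatic ring. With no number for compound 2, the size of this step cannot be read from the data. A modest step toward stronger inhibition is expected, though this is only a judgement. Among the compounds with values here, the sole measured anchor is compound 1 at 8000 nM. For compound 3 the estimated value in this assay is 5000 nM, with an expected range of 1500 nM to 20000 nM.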

Compound 3, half-maximal inhibitory concentration: > 10000 nM
Compound 3 gave a limit, no number (the forecaster's own chance of this, stated with the estimate: 10%); middle value at least 2.0-fold (0.30 log units) from the limit.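

In this assay compound 3 gives > 10000 nM, which is a limit and not a number. With 3-(methylamino)propyl in place of 3-aminophenyl on a nitrogen on an aromatic ring, the data show an at least 1.2-fold higher number from compound 1 to compound 3 (0.09 log units; that floor lies within the scatter), so this chain gives no sign of stronger inhibition than the 3-aminophenyl group, yet the two compounds cannot be told apart. The comparison at this position therefore rests on a single limit: the limit of > 10000 nM in this assay, at which 1 of the 3 values shown sits.

The step from compound 2 to compound 3 cannot be read, so the change from (2-hydroxyethyl)amino to (3-(methylamino)propyl)amino has no size. Also open, going by these compounds, is whether a dimethylamino group at the end of the chain, a longer chain or a carboxylic acid there would give a number in this assay.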